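Swapping diethylamino for dibutylamino on a side chain

The compounds below may be only part of what the source reports. "The series", "measured", "known", "first", "only" and "open" are said of these compounds alone.

Three compounds share one core and differ only in the group on an oxygen on an aromatic ring. In a functional assay on LNCaP cells (Homo sapiens) for antiproliferative activity, read by WST assay, with a stated time of 3 days (a lower number here means a stronger inhibitor, a higher number a weaker inhibitor), compound 1 `CCCCCCOc1c(-c2cc(OC)c(OC)c(OC)c2)oc2ccccc2c1=O`, which carries hexyl, gives 19600 nM. Compound 2 `CCC(C)Oc1c(-c2cc(OC)c(OC)c(OC)c2)oc2ccccc2c1=O`, which carries sec-butyl, gives 9300 nM. Compound 3 `CCN(CC)CCCCOc1c(-c2cc(OC)c(OC)c(OC)c2)oc2ccccc2c1=O`, which carries 4-(diethylamino)butyl, gives 13500 nM. Compound 3 thus falls among these numbers, within the usual scatter of both others.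

Compound 4 `CCCCN(CCCC)CCCCOc1c(-c2cc(OC)c(OC)c(OC)c2)oc2ccccc2c1=O` has dibutylamino in place of diethylamino on a saturated chain carbon, four bonds along the chain from an oxygen on an aromatic ring. Among the compounds with values here, no measured step makes this exact swap. The closest evidence is the change from ethyl to diethylamino at that same place, which gave a 1.5-fold lower number from compound 1 to compound 3 (0.16 log units; within the scatter). Replacing sec-butyl with the whole 4-(diethylamino)butyl group gave a 1.5-fold higher number from compound 2 to compound 3 (0.16 log units; within the scatter). The remaining step, sec-butyl in place of hexyl, gave a 2.1-fold lower number from compound 1 to compound 2 (0.32 log units; beyond the scatter), which is modest.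

With only small steps to go on, no change beyond the scatter is expected in this assay, and the estimated step is a 1.4-fold lower number from compound 3 to compound 4 (0.13 log units; within the scatter). The expected value for compound 4 is 10000 nM, within an estimated range of 4500 nM to 22000 nM.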

Compound 4, half-maximal inhibitory concentration: 7800 nM
Compound 4: middle estimate off by 1.3-fold (0.11 log units), on the high side, within the range that was stated.
By their numbers in this assay, from the lowest: compounds 4, 2, 3 and 1 (each within the scatter of the next, the first and the last beyond it).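

In this assay, the larger dibutylamino group, with 9 heavy atoms against 5 for diethylamino, gives a 1.7-fold lower number from compound 3 to compound 4 (0.24 log units; within the scatter), so at this place on the chain the amine can grow by two butyl groups' worth of carbon in place of two ethyl groups without a change that stands clear of the scatter. Measured against the hexyl compound, the new side chain gives a 2.5-fold lower number from compound 1 to compound 4 (0.40 log units; beyond the scatter), a modest step but one beyond the scatter, whereas the diethylamino side chain, at a 1.5-fold lower number from compound 1 to compound 3 (0.16 log units; within the scatter), stayed within it. Nothing available explains either step.

The compounds shown leave open how the chain between the oxygen and the amine matters, since a shorter 3-(dibutylamino)propyl group would test that directly while keeping dibutylamino in place. They also leave open whether an open-chain amine is needed at all, which a ring amine such as piperidine or morpholine, or a carboxylic acid at the end of the same chain, could help to show.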